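Cytotoxicity notes: benzyl swap from compound 2 to compound 4

This account rests on a few compounds, and the source may have more. Where it says the series, first, only, none or still open, it means among the compounds named here.

Compound 1 `Cc1cccc(-c2cccc(NCc3cncn3Cc3ccccc3)c2)c1C` and compound 3 `COc1ccc(NCc2cncn2Cc2ccc(-c3ccccc3)cc2N)cc1-c1ccccc1` have both been run in a toxicity assay on NIH3T3 cells (Mus musculus) for cytotoxicity, read by resazurin assay; on this read-out higher numbers stand for an effect only at larger amounts of compound and lower numbers for an effect already at smaller amounts. For compound 1 the result is only a limit of the assay, > 1000 nM. For compound 3 the result is likewise a limit, > 1000 nM. Compound 2 `COC(=O)c1ccc(NCc2cncn2Cc2ccccc2OC)cc1-c1ccccc1` has no number in this assay; its entry reads "not determined" (no result reported). Compound 2 therefore stands nowhere on the scale, whereas the two measured neighbours sit at the limit of > 1000 nM in this assay, at which 2 of the 3 values shown sit. Compound 4 `COC(=O)c1ccc(NCc2cncn2Cc2cccc([N+](=O)[O-])c2)cc1-c1ccccc1` is next to be measured in this assay. It differs from compound 2 by 3-nitrophenyl in place of 2-methoxyphenyl on a saturated chain carbon bound to an aromatic nitrogen. Among the compounds with values here, no measured step covers this change. The expectation is no step beyond the scatter, with compound 4 also reaching the limit. For compound 4 in this assay the estimate is 3000 nM, with a range from 1000 nM to 30000 nM.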

Compound 4, half-maximal effective concentration: > 10000 nM
Compound 4: only a limit was reported; the forecaster's own chance of this, stated with the estimate: 75%; middle value at least 3.3-fold (0.52 log units) from the limit.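

No step can be read between compound 2 and compound 4: compound 2 carries no number and compound 4 only a limit, > 10000 nM. Going by these compounds, whether 3-nitrobenzyl in place of 2-methoxybenzyl shifts cytotoxicity at all stays open.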